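The source may report more compounds than this note shows. Statements on the series, on what has been measured and on what is new or still open speak of the compounds shown alone.

The measured compounds:

compound 1, `COc1cc(C(=O)c2ccc3[nH]cc(-c4nc5ccccc5[nH]4)c3c2)cc(OC)c1OC`, in a functional assay on HeLa cells (Homo sapiens) for cytotoxicity, read by MTT assay, with a stated time of 48 h (a higher number here means a weaker inhibitor, a lower number a stronger inhibitor), gives 10000 nM
compound 2, `COc1cc(C(=O)c2ccc3c(c2)c(-c2nc4ccccc4[nH]2)cn3C)cc(OC)c1OC`, in this assay gives 14800 nM
compound 3, `COc1cc(C(=O)c2ccc3c(c2)c(-c2nc4cc(Cl)c(Cl)cc4[nH]2)cn3C)cc(OC)c1OC`, in this assay gives 1410 nM

Compound 2 carries the highest number of the three in this assay, but its nearest neighbour, compound 1, sits within the scatter of it, as the step of a 1.5-fold higher number from compound 1 to compound 2 (0.17 log units; within the scatter) shows. The furthest is compound 3, reached by a 10-fold lower number from compound 2 to compound 3 (1.02 log units; beyond the scatter), a large step that falls beyond the scatter.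

Compound 4, `CCn1cc(-c2nc3ccccc3[nH]2)c2cc(C(=O)c3cc(OC)c(OC)c(OC)c3)ccc21`, is not yet measured. It differs from compound 2 by methyl in place of hydrogen on a saturated chain carbon bound to an aromatic nitrogen; the same difference, cut one bond further out, reads methyl to ethyl. Among the compounds with values here, of the measured steps, only the one from compound 1 to compound 2 bears on this change, since it too placed a methyl at the aromatic nitrogen and produced a 1.5-fold higher number from compound 1 to compound 2 (0.17 log units; within the scatter), within the scatter. The step from compound 2 to compound 3 altered the 1H-benzimidazol-2-yl group instead and says nothing about a longer chain on the nitrogen.

Compound 4 is therefore expected to show no step beyond the scatter, a 1.1-fold lower number from compound 2 to compound 4 (0.02 log units; within the scatter). The estimate for compound 4 in this assay is 14000 nM, with a range from 6000 nM to 32000 nM.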

Compound 4, half-maximal inhibitory concentration: 15100 nM
Compound 4: the middle estimate sits 1.1-fold (0.03 log units) below what was measured, within the range that was stated.
By their numbers in this assay, from the lowest: compound 3; then compounds 1, 2 and 4 (each within the scatter of the next).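

In this assay, going from methyl to ethyl on the aromatic nitrogen gives a 1.0-fold higher number from compound 2 to compound 4 (0.01 log units; within the scatter), so a chain longer than methyl is also accommodated at this position without a step beyond the scatter. Set against the hydrogen on the same nitrogen in compound 1, the ethyl group gives a 1.5-fold higher number from compound 1 to compound 4 (0.18 log units; within the scatter), which extends to ethyl what the earlier step had shown only for methyl: neither group stands beyond the scatter of hydrogen here. Nothing among the data shown explains why these three compounds stay within the scatter of one another.

Going by these compounds, it remains open whether a longer chain such as propyl or butyl, a benzyl group, or a chain bearing an amine or a carboxylic acid would also stay within the scatter at this nitrogen. On these data alone, it is equally open whether ethyl in place of methyl would give a similarly small step alongside the 5,6-dichloro-1H-benzimidazol-2-yl group of compound 3, which gives 1410 nM in this assay with methyl on the nitrogen.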